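From 4-bromophenyl to 4-methylphenyl: working notes

The source may hold more compounds than are shown below. What is called first, only, known or untested is meant among the compounds shown, and "the series" means these compounds.

In a functional assay on MOLT-4 cells (Homo sapiens) for antiproliferative activity, with a stated time of 48 h (a lower number here means a stronger inhibitor, a higher number a weaker inhibitor), compound 1 `C=C(Br)C(=O)Nc1ccc(/C=C/C(=O)c2ccc(F)cc2)cc1` gives 660 nM and compound 2 `C=C(Br)C(=O)Nc1ccc(/C=C/C(=O)c2ccc(Br)cc2)cc1` gives 680 nM. Going by the values given here, compound 2 therefore stands level with compound 1, the only other measured compound, and the two cannot be separated within the scatter.

Compound 3 `C=C(Br)C(=O)Nc1ccc(/C=C/C(=O)c2ccc(C)cc2)cc1` has not yet been measured. It carries methyl in place of bromo on an aromatic carbon, para to a large group: methyl in place of bromo on an aromatic carbon.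

Among the compounds with values here, only one measured step bears on this change. It concerns the same aromatic carbon, with bromo in place of fluoro: a 1.0-fold higher number from compound 1 to compound 2 (0.01 log units; within the scatter), which lies within the scatter. Within the data shown here, that single step shows no sensitivity to the swap between those two groups, but no methyl compound has been measured, so the evidence is indirect. No step beyond the scatter is therefore expected in this assay, and the data indicate no direction.

The estimated change is a 1.0-fold higher number from compound 2 to compound 3 (0.01 log units; within the scatter). Compound 3 is expected at 700 nM, with an estimated range of 350 nM to 1400 nM.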

Compound 3, half-maximal inhibitory concentration: 1700 nM
The estimate for compound 3 lay 2.4-fold (0.39 log units) below the measured number, and the stated range ends below it.
By their numbers in this assay, from the lowest: compounds 1 and 2 (each within the scatter of the next); then compound 3.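

In this assay this aromatic carbon proves sensitive to the group it carries, which the fluoro and bromo pair could not reveal: a 1.0-fold higher number from compound 1 to compound 2 (0.01 log units; within the scatter) stays within the scatter, whereas a 2.5-fold higher number from compound 2 to compound 3 (0.40 log units; beyond the scatter) and a 2.6-fold higher number from compound 1 to compound 3 (0.41 log units; beyond the scatter) both pass beyond it, leaving compound 3 as the weakest of the three. Among these three compounds, the two halogens therefore stand level and methyl alone separates from them, so the flat fluoro and bromo step says nothing about groups outside that pair. No measurement shown here accounts for the loss on going to methyl.

Going by these compounds, what remains open is whether the higher number belongs to methyl specifically or to non-halogen groups on this carbon generally, which a methoxy group or an amine in the same place would help to settle. On these data alone, it is also open whether chloro would stand level with fluoro and bromo, and whether a longer chain such as ethyl would move the number further from that of methyl.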